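The source may report more compounds than this note shows. Statements on the series, on what has been measured and on what is new or still open speak of the compounds shown alone.

Compound 1 `O=C(O)c1[nH]c(C2CCCN2S(=O)(=O)c2cc(Cl)cc(Cl)c2)nc1-c1ccc2ccccc2c1` gives 8% in an assay on Jurkat cells for displacement of a labelled ligand from integrin alpha-4 (Homo sapiens), tested at 100 uM; a higher number here means more inhibition at the concentration tested (going by the name of the read-out), a lower number less inhibition.
Compound 2 `O=C(O)c1nc(C2CCCN2S(=O)(=O)c2cc(Cl)cc(Cl)c2)sc1-c1ccc2ccccc2c1` gives 19% in this assay.

Of these two numbers compound 1 stands lowest, and compound 2 lies higher by a margin beyond the usual scatter; the two structures differ in more than one place, so nothing more than that comparison is shown. Compound 3 `O=C(O)c1[nH]c(C2CCCN2S(=O)(=O)c2cc(Cl)cc(Cl)c2)nc1Cc1ccc2ccccc2c1` differs from compound 1 by a single change: (naphthalen-2-yl)methyl in place of naphthalen-2-yl on an aromatic carbon. Among the measured compounds shown here, no measured pair shows a step of this kind, so compound 3 is expected to sit close to compound 1, with a step of a number 2 percentage points higher from compound 1 to compound 3 (within the scatter) that is expected to stay within the scatter. Compound 3 is estimated at 10%, with a range from 0% to 25%.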

Compound 3, a percentage reported as inhibition, at one concentration (the size of the read-out at that concentration, not a potency): 30%
The estimate for compound 3 lay 20 percentage points below the measured number; measured number above the stated range.
By their numbers in this assay, from the lowest: compound 1; then compound 2; then compound 3.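

In this assay, placing (naphthalen-2-yl)methyl instead of naphthalen-2-yl on the aromatic carbon next to the ring atom that bears a carboxy group gives a step of a number 22 percentage points higher from compound 1 to compound 3 (beyond the scatter). This is the first single-place change shown at this position, and it shows that the read-out responds to one added carbon while both aromatic rings stay in the group. Nothing in the data accounts for this rise.

On these data alone, it remains open whether a longer chain, such as 2-(naphthalen-2-yl)ethyl, or an oxygen atom in place of the added carbon would raise the number further.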